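The source may report more compounds than this note shows. Statements on the series, on what has been measured and on what is new or still open speak of the compounds shown alone.

Going by the values given here, compound 2, `O=C(NCc1cc(Cl)ccc1-n1cnnn1)[C@@H]1C[C@@H]2C[C@@H]2N1C(=O)[C@H](O)Cn1cccn1`, holds the lowest of the two numbers measured so far in an ADME assay on Caco-2 cells (Homo sapiens) for permeability, read by LC-MS, in the apical to basolateral direction, with a stated time of 60 min, at pH 6.5; on this read-out lower numbers stand for lower permeability and higher numbers for higher permeability; in that assay compound 2 gives 0.45 10^-6 cm/s. The other measured compound is compound 1, `CC(C)(C)OC[C@@H](O)C(=O)N1[C@H](C(=O)NCc2cc(Cl)ccc2-n2cnnn2)C[C@@H]2C[C@@H]21`, which in this assay gives 4.5 10^-6 cm/s. Among the compounds with values here, the one measured step, a 10-fold lower number from compound 1 to compound 2 (1.00 log units; beyond the scatter), went with 1H-pyrazol-1-yl in place of tert-butoxy on a saturated chain carbon, two bonds along the chain from a carbonyl carbon and an oxygen on a saturated carbon.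

Compound 3, `CC(C)(C)[C@@H](O)C(=O)N1[C@H](C(=O)NCc2cc(Cl)ccc2-n2cnnn2)C[C@@H]2C[C@@H]21`, differs from compound 2 in a single place: tert-butyl in place of (1H-pyrazol-1-yl)methyl on a saturated chain carbon bound to a carbonyl carbon and an oxygen on a saturated carbon. Within the data shown here, this change largely undoes the one that separates compound 1 from compound 2: the five-membered aromatic ring with 2 hetero atoms leaves again, and a group of 4 carbon atoms with no hydrogen-bond acceptors enters, though here as tert-butyl rather than tert-butoxy. Since the step from compound 1 to compound 2 was a clear drop, the reverse direction points to a rise of similar size, so the step of an 11-fold higher number from compound 2 to compound 3 (1.05 log units; beyond the scatter) is expected to be upward and beyond the scatter. Compound 3 is therefore expected to give 5 10^-6 cm/s, with a likely range from 2 10^-6 cm/s to 12 10^-6 cm/s.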

Compound 3, apparent permeability: 16 10^-6 cm/s
Compound 3: middle estimate off by 3.2-fold (0.51 log units), on the low side; measured number above the stated range.
By their numbers in this assay, from the lowest: compound 2; then compound 1; then compound 3.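

Placing tert-butyl on this saturated chain carbon gives a 36-fold higher number from compound 2 to compound 3 (1.55 log units; beyond the scatter) in this assay, so the (1H-pyrazol-1-yl)methyl of compound 2 and the tert-butyl of compound 3 stand far apart on this read-out. The position also separates two groups that both carry a tert-butyl unit: the change from (tert-butoxy)methyl to tert-butyl gives a 3.6-fold higher number from compound 1 to compound 3 (0.55 log units; beyond the scatter), which makes compound 3 the highest of the three, with its steps to both others beyond the scatter. Nothing shown here accounts for how widely these groups differ, so the link between group and number remains an observation only.

The compounds shown leave open whether the gap between compound 1 and compound 3 follows the oxygen or the extra chain length, a question that a 2,2-dimethylpropyl group, the chain of compound 1 with its oxygen replaced by a carbon, could help to separate. They also leave open where a benzyl group, with an all-carbon ring in place of the pyrazole, or a basic dimethylaminomethyl group would fall at this same carbon.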